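The compounds below may be only part of what the source reports. "The series", "measured", "known", "first", "only" and "open" are said of these compounds alone.

Measured in a functional assay on KB cells (Homo sapiens) for inhibition, read by MTT assay, with a stated time of 24 h, tested at 100 ug/mL (a lower number here means less inhibition of growth, a higher number more inhibition of growth at the concentration tested), so far

Compound 1 (`O=C(CCCCC(S)CCS)Nc1ccccc1`) gives 15.8%
Compound 2 (`O=C(CCCCC(S)CCS)Nc1ccccc1Cl`) gives "not active" (no number reported)
Compound 3 (`O=C(CCCCC(S)CCS)Nc1cccc(Cl)c1`) gives 8.04%

The values of compound 1 and compound 3 lie within the scatter of each other, so neither can be ranked over the other, and compound 2 offers no number for comparison. Compound 1 is therefore the reference point here, with one numerical neighbour and one entry without a number.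

Compound 4 (`O=C(CCCCC(S)CCS)Nc1ccc(OC(F)(F)F)cc1`) has not yet been measured. It differs from compound 1 by trifluoromethoxy in place of hydrogen on an aromatic carbon; this is trifluoromethoxy in place of hydrogen on an aromatic carbon, para to a large group.

Going by the values given here, no measured compound carries trifluoromethoxy, so the evidence is indirect. Among the compounds with values here, the one measured step (a number 7.8 percentage points lower from compound 1 to compound 3 (within the scatter)) is chloro in place of hydrogen on an aromatic carbon, and it does not leave the scatter. Compound 2 also carries chloro and came back without a number, so a result without a number is possible for compound 4 as well. A small step at most is therefore expected, with a slight lean downward.

The estimated step (a number 5.8 percentage points lower from compound 1 to compound 4 (within the scatter)) is expected to stay within the scatter. For compound 4 the expected value in this assay is 10%, with an estimated range from 2% to 22%.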

Compound 4, percent growth inhibition at one concentration: 73.3%
Compound 4: middle estimate off by 63.3 percentage points, on the low side; the whole stated range lies below it.
By their numbers in this assay, from the lowest: compounds 3 and 1 (each within the scatter of the next); then compound 4.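

In this assay, going by these compounds alone, trifluoromethoxy in place of hydrogen on an aromatic carbon, para to a large group, gives a number 57.5 percentage points higher from compound 1 to compound 4 (beyond the scatter), the first step to leave the scatter. The aromatic ring of compound 1 can therefore carry a change that strongly alters growth inhibition at the concentration tested, which the chloro step did not show, since it gives a number 7.8 percentage points lower from compound 1 to compound 3 (within the scatter) and compound 2 returned no number. The data shown contain no measurement that would explain this large step.

The compounds shown do not settle whether the rise is specific to trifluoromethoxy or would also appear with another group at the same place, and a methoxy or trifluoromethyl group there would help separate these two readings. They also leave open how the effect of compound 4 depends on concentration, and whether it survives a change elsewhere in the shared core, such as a carboxylic acid in place of one of the thiol groups.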